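A ring swap on the way to compound 4

The compounds below may be only part of what the source reports. "The series", "measured", "known", "first", "only" and "open" are said of these compounds alone.

In a functional assay on MT2 cells (Homo sapiens) for cytotoxicity, read by MTT assay (a higher number here means that more compound is tolerated, a lower number that less compound is tolerated), compound 1 (`CCc1ccc(Nc2nccs2)cc1OCC=C(C)C`) gives 31000 nM and compound 2 (`Clc1ccc(Nc2nccs2)cc1OCc1ccsc1`) gives 38000 nM while compound 3 (`N#Cc1ccc(Nc2nccs2)cc1OCc1ccsc1`) gives 1100 nM as the lowest of the three numbers. Compound 4 (`N#Cc1ccc(Nc2nccs2)cc1OCC1=CCCC1`) has not been measured. Its change from compound 3 is cyclopent-1-en-1-yl in place of thiophen-3-yl on a saturated chain carbon bound to an oxygen on an aromatic ring and it sits on a saturated chain carbon bound to an oxygen on an aromatic ring. Among the compounds with values here, the only measured step, a 35-fold lower number from compound 2 to compound 3 (1.54 log units; beyond the scatter) with cyano in place of chloro on an aromatic carbon, is large but lies at a different place, so it does not measure this swap directly. Compound 1 also lacks thiophen-3-yl, but with 31000 nM it has no cyano either, so its number cannot separate the two changes. Compound 4 keeps the cyano of compound 3, so only a modest move is expected, and upward seems likelier than downward. The estimated step is a 2.3-fold higher number from compound 3 to compound 4 (0.36 log units; beyond the scatter) in size and direction. In this assay compound 4 is therefore expected at 2500 nM with an estimated range from 700 nM to 10000 nM as its likely span.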

Compound 4, half-maximal cytotoxic concentration: 1700 nM
The estimate for compound 4 lay 1.5-fold (0.17 log units) above the measured number; the range from low to high includes it.
By their numbers in this assay, from the lowest: compounds 3 and 4 (each within the scatter of the next); then compounds 1 and 2 (each within the scatter of the next).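

In this assay the swap on a saturated chain carbon bound to an oxygen on an aromatic ring gives a 1.5-fold higher number from compound 3 to compound 4 (0.19 log units; within the scatter) and so stays within the scatter. In this one pair, the aromatic five-membered ring with its sulfur can give way to a non-aromatic five-membered ring of carbon only, with the same number of heavy atoms, and the two numbers cannot be told apart. Nothing available explains why the two rings read alike.

As far as these compounds go, it remains open whether the number also holds with a saturated cyclopentyl ring, a phenyl ring or a chain carrying an amine at this place. From the compounds shown here alone, it is also open whether chloro in place of cyano would move the number as far with cyclopent-1-en-1-yl on the chain as it does with thiophen-3-yl.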